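Adding Trifluoromethyl to Compound 3: A Small Expected Change

A few compounds are considered here, and "the series" means these few. Any claim that something is new, unique, unknown or untested is made for them only; others in the source may bear on it.

The three measured compounds were all tested in a functional assay on MCF7 cells (Homo sapiens) for antiproliferative activity, read by MTT assay, with a stated time of 72 h; a lower number here means a stronger inhibitor, a higher number a weaker inhibitor.
Compound 1 `O=C(Nc1ccc(Cl)c(-c2nnc3c(Cl)cccn23)c1)c1ccc(C(F)(F)F)cc1F` — 62800 nM
Compound 2 `CS(=O)(=O)c1ccc(C(=O)Nc2ccc(Cl)c(-c3nnc4c(Cl)cccn34)c2)c(Cl)c1` — > 100000 nM, which is a limit of the assay rather than a number
Compound 3 `O=C(Nc1ccc(Cl)c(-c2nnc3c(Cl)cccn23)c1)c1ccccc1Cl` — 92200 nM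

Compound 3 gives the highest of the two numbers shown; its nearest neighbour is compound 1, and the gap between them lies within the usual scatter, so the two cannot be told apart. Among the compounds with values here, the only measured step, an at least 1.0-fold lower number from compound 2 to compound 3 (0.03 log units; that floor lies within the scatter), concerns the loss of a methylsulfonyl group and, with its floor sitting within the scatter, offers no direction; the limit of > 100000 nM in this assay, at which 1 of the 3 values shown sits, marks the one value that is a limit.

Compound 4 `O=C(Nc1ccc(Cl)c(-c2nnc3c(Cl)cccn23)c1)c1ccc(C(F)(F)F)cc1Cl` is the unmeasured compound. Its change from compound 3 is trifluoromethyl in place of hydrogen on an aromatic carbon. Within the data shown here, no measured step involves a trifluoromethyl group, so the expectation rests on compound 1, which already carries trifluoromethyl and gives 62800 nM, a number close to that of compound 3. The step of a 1.3-fold lower number from compound 3 to compound 4 (0.12 log units; within the scatter) is therefore expected to stay within the scatter. Compound 4 is estimated at 70000 nM, between 30000 nM and 150000 nM.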

Compound 4, half-maximal inhibitory concentration: 81600 nM
The estimate for compound 4 lay 1.2-fold (0.07 log units) below the measured number; low and high end bracket the measured number.
By their numbers in this assay, from the lowest: compounds 1, 4 and 3 (each within the scatter of the next). At a limit, above all of these: compound 2.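

The first measured step involving trifluoromethyl in this assay is a 1.1-fold lower number from compound 3 to compound 4 (0.05 log units; within the scatter), so on this aromatic carbon, meta to a chloro group and para to a large group, trifluoromethyl and hydrogen cannot be told apart. Within the data shown here, the other group on this ring can be compared too, which the earlier compounds did not allow with trifluoromethyl held in place: the result is a 1.3-fold higher number from compound 1 to compound 4 (0.11 log units; within the scatter), so chloro and fluoro cannot be told apart here either. Trifluoromethyl in place of methylsulfonyl gives an at least 1.2-fold lower number from compound 2 to compound 4 (0.08 log units; that floor lies within the scatter), and with that floor within the scatter this step shows no direction. Compound 2 gives a limit and not a number: the limit of > 100000 nM in this assay, at which 1 of the 4 values shown sits.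

Going by these compounds, whether an amine, a carboxylic acid or a longer chain on this same carbon would give a step beyond the scatter from compound 3 remains open. Also open is whether any change to the shared core, rather than to the groups on this ring, would move the number in this assay by more than the scatter, since every readable step shown here stays within it.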